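Ester-to-amine swap on the amide chain across two cores

The source may hold more compounds than are shown below. What is called first, only, known or untested is meant among the compounds shown, and "the series" means these compounds.

Compound 1 `CCn1c(C(=O)NCCC(=O)OC)ccc1C(CC)(CC)c1ccc(C#CC(O)(CC)CC)c(C)c1` and compound 2 `CCN(CC)CCCNC(=O)c1ccc(C(CC)(CC)c2ccc(C#CC(O)(CC)CC)c(C)c2)n1CC` share one core; compound 3 `CCn1cc(C(CC)(CC)c2ccc(C#CC(O)(CC)CC)c(C)c2)cc1C(=O)NCC(=O)OC` and the unmeasured compound 4 `CCN(CC)CCNC(=O)c1cc(C(CC)(CC)c2ccc(C#CC(O)(CC)CC)c(C)c2)cn1CC` share another, and the difference between the two cores is not broken down here. In an assay on cells for agonist activity at vitamin D3 receptor (Homo sapiens), read by microscopy (a lower number here means that less compound is needed, a higher number that more compound is needed for the effect), compound 1 sits at > 50 nM, which is a limit of the assay and not a number. In this assay compound 2 gives 68.9 nM, while compound 3 gives 288 nM, the highest of the two numbers and beyond the scatter from compound 2. From compound 1 to compound 2 the change is (diethylamino)methyl in place of methoxycarbonyl on a saturated chain carbon, two bonds along the chain from an amide-type nitrogen; the step is a step that the limit leaves unreadable from compound 1 to compound 2 because of the limit of > 50 nM in this assay, at which 1 of the 3 values shown sits. From compound 3 to compound 4 the change is (diethylamino)methyl in place of methoxycarbonyl on a saturated chain carbon bound to an amide-type nitrogen: the same kind of change, but placed on a saturated chain carbon bound to an amide-type nitrogen rather than two bonds along the chain from an amide-type nitrogen. With the earlier step unreadable, no measured size for this kind of change is available, so the expectation for compound 4 rests mainly on the value of compound 3, 288 nM, with a wide range. A step of a 1.7-fold lower number from compound 3 to compound 4 (0.23 log units; within the scatter) is expected from compound 3 to compound 4. Compound 4 is estimated at 170 nM, between 50 nM and 600 nM.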

Compound 4, half-maximal effective concentration: 6.98 nM
For compound 4 the middle estimate is 24-fold (1.39 log units) above the measured one, and the stated range ends above it.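

In this assay, (diethylamino)methyl in place of methoxycarbonyl on a saturated chain carbon bound to an amide-type nitrogen gives a 41-fold lower number from compound 3 to compound 4 (1.62 log units; beyond the scatter), so the change has a large readable effect on the core of compound 3. On the core of compound 1 the same kind of change sits two bonds along the chain from an amide-type nitrogen, and compound 1 stands at a limit, not a number, leaving that step unreadable: the limit of > 50 nM in this assay, at which 1 of the 4 values shown sits.
The series therefore gives a size for this change on one core only and does not show whether that size carries over to the other core, where the place on the chain also differs.

Still open is how much of the step belongs to the diethylamino group itself, since the compounds shown include no carboxylic acid, primary amine or dimethylamino group on these chains. Also open, as far as these compounds go, is how each core responds when both carry the same chain, which would separate the effect of the core from that of the place of the change.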